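The compounds below may be only part of what the source reports. "The series", "measured", "known", "first", "only" and "open" are said of these compounds alone.

Of the compounds shown here, three of a shared core have been tested in a functional assay on B16 cells (Mus musculus) for cytotoxicity, read by MTT assay, with a stated time of 72 h; on this read-out higher numbers stand for weaker inhibition and lower numbers for stronger inhibition. Compound 1 `COc1cc(C2=NN(C(C)=O)C(c3ccc([N+](=O)[O-])cc3)C2)cc(OC)c1OC` gives 51000 nM, and that number stands alongside compound 2 `COc1ccc(OC)c(C2=NN(C(C)=O)C(c3ccc(OC)c([N+](=O)[O-])c3)C2)c1` at 58000 nM and compound 3 `COc1ccc(C2CC(c3cc(OC)c(OC)c(OC)c3)=NN2)cc1OC` at 44000 nM, all three within the scatter of one another, so none of them can be called weaker or stronger than the rest. The whole set sits in a region of very weak inhibition.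

Compound 4 `COc1cccc(C2CC(c3cc(OC)c(OC)c(OC)c3)=NN2C(C)=O)c1` has not yet been measured in this assay. It differs from compound 1 in one place: 3-methoxyphenyl in place of 4-nitrophenyl on a saturated ring carbon. The acetyl group and the trimethoxyphenyl group of the core are kept. Among the compounds with values here, with no step between measured compounds available to guide the size of this change, and with all three known values so close together, the step is expected to be small in either direction, none beyond the scatter. The expected step of a 1.0-fold lower number from compound 1 to compound 4 (0.01 log units; within the scatter) therefore stays within the usual spread. Compound 4 is estimated at 50000 nM, with a range from 20000 nM to 120000 nM.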

Compound 4, half-maximal inhibitory concentration: > 100000 nM
Compound 4: no number, only a limit (the forecaster's own chance of this, stated with the estimate: 15%); at least 2.0-fold (0.30 log units) between middle value and limit.
By their numbers in this assay, from the lowest: compounds 3, 1 and 2 (each within the scatter of the next). At a limit, above all of these: compound 4.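

In this assay the value of compound 4, > 100000 nM, is a limit of the assay and not a number. Within the data shown here, this gives the first readable step at this saturated ring carbon, with 3-methoxyphenyl in place of 4-nitrophenyl: an at least 1.9-fold higher number from compound 1 to compound 4 (0.29 log units; that floor lies within the scatter). The change brings no gain in inhibition, but its size stays unfixed, so it cannot be called a loss beyond the scatter, and the one reading that bounds it is this: the limit of > 100000 nM in this assay, at which 1 of the 4 values shown sits.

The compounds shown leave open whether a phenyl group carrying an amine or a carboxylic acid at this position would bring the number down into a range where steps can be measured. They also leave open whether a longer chain in place of the acetyl group would change the reading when 3-methoxyphenyl is kept.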